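Working notes: from compound 2 to compound 4

The source may hold more compounds than are shown below. What is called first, only, known or untested is meant among the compounds shown, and "the series" means these compounds.

Measured compounds so far:
Compound 1, `CC1(C)Cc2c(ccc(C(=O)/C=C/c3ccc(Cl)cc3Cl)c2OCc2ccccc2)O1`. In a functional assay on NCI-H460 cells (Homo sapiens) for antiproliferative activity, read by MTT assay, with a stated time of 48 h (a higher number here means a weaker inhibitor, a lower number a stronger inhibitor), compound 1 gives > 100000 nM, which is a limit of the assay and not a number.
Compound 3, `CC1(C)Cc2c(ccc(C(=O)/C=C/c3ccc(Br)cc3)c2OCc2ccccc2)O1`. In this assay compound 3 gives > 100000 nM, again a limit.
Compound 2, `CC1(C)Cc2c(ccc(C(=O)/C=C/c3cn(-c4ccccc4)nc3-c3ccc(Cl)cc3)c2OCc2ccccc2)O1`. In this assay compound 2 gives > 100000 nM, a limit as well.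

Going by the values given here, the single step between measured compounds, a step that the two limits leave unreadable from compound 1 to compound 3, cannot be read because both of its ends are limits. Compound 2 thus stands where every measured compound stands, at the limit described by the limit of > 100000 nM in this assay, at which 3 of the 3 values shown sit; nothing separates it from compound 1 or compound 3 on the numbers shown.

Compound 4 is `Cc1ccc(-c2nn(-c3ccccc3)cc2/C=C/C(=O)c2ccc3c(c2OCc2ccccc2)CC(C)(C)O3)cc1`. It differs from compound 2 by methyl in place of chloro on an aromatic carbon. Among the compounds with values here, no measured step concerns this change, and the one step available is unreadable, so no size of step can be derived from the measured compounds. The expectation for compound 4 can rest only on compound 2 sitting at the limit.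

Compound 4 is expected to give about 100000 nM, in the range 30000 nM to 300000 nM, most probably reported once more as a limit only. The expected step is therefore a number no higher from compound 2 to compound 4 (the limit leaves the size open), none beyond the scatter.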

Compound 4, half-maximal inhibitory concentration: > 100000 nM
Compound 4: only a limit was reported; the forecaster's own chance of this, stated with the estimate: 85%; the middle value sits exactly at the limit.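

Going by these compounds alone, the step between compound 2 and compound 4 cannot be read, as both ends are limits of the assay and not numbers, so no new step follows. The compounds shown leave open whether any change on the shared core gives a readable value in this assay: the limit of > 100000 nM in this assay, at which 4 of the 4 values shown sit.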